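The source may hold more compounds than are shown below. What is called first, only, known or untested is meant among the compounds shown, and "the series" means these compounds.

For the measured compounds named here, in a functional assay on L1210 cells (Mus musculus) for antiproliferative activity, read by cell counting, with a stated time of 96 h (on this read-out lower numbers stand for stronger inhibition and higher numbers for weaker inhibition), compound 1 `CC(Nc1ccccc1Oc1cccc(F)c1)=C1C(=O)CC(c2ccccc2)CC1=O` gives 330 nM and compound 2 `COc1cc(Oc2ccccc2NC(C)=C2C(=O)CC(c3ccccc3)CC2=O)ccc1N` gives 26 nM, the lower of the two numbers so far. Compound 3 `CCOc1ccccc1NC(C)=C1C(=O)CC(c2ccccc2)CC1=O` has not yet been measured. It differs from compound 2 as follows: ethyl in place of 4-amino-3-methoxyphenyl on an oxygen on an aromatic ring. The ring that compound 2 carries on that oxygen is thus absent from compound 3. Going by the values given here, only one measured step bears on this change: a 13-fold lower number from compound 1 to compound 2 (1.10 log units; beyond the scatter), a large step in which 4-amino-3-methoxyphenyl replaced 3-fluorophenyl on the same oxygen. Among the compounds with values here, no measured compound lacks that ring, so the size of the new step is uncertain, but a move to a higher number, beyond the scatter, is expected. The expected change is a 58-fold higher number from compound 2 to compound 3 (1.76 log units; beyond the scatter). The estimated value for compound 3 is 1500 nM, within an expected range of 300 nM to 8000 nM.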

Compound 3, half-maximal inhibitory concentration: 190 nM
Compound 3: middle estimate off by 7.9-fold (0.90 log units), on the high side, outside the stated range (below it).
By their numbers in this assay, from the lowest: compound 2; then compounds 3 and 1 (each within the scatter of the next).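

In this assay, ethyl in place of 4-amino-3-methoxyphenyl gives a 7.3-fold higher number from compound 2 to compound 3 (0.86 log units; beyond the scatter), so the change at this oxygen has a modest effect, beyond the scatter. Ethyl in place of 3-fluorophenyl gives a 1.7-fold lower number from compound 1 to compound 3 (0.24 log units; within the scatter), which lies within the scatter, so these two groups cannot be told apart here even though ethyl has no ring. Having a ring on this oxygen is therefore not enough by itself, and among these three compounds only the 4-amino-3-methoxyphenyl group stands apart.

Nothing available explains why this group stands apart. On these data alone, it remains open whether the amine or the methoxy matters more, which a phenyl ring carrying only one of them could show, and whether a longer chain such as butyl behaves like ethyl.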